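This account rests on a few compounds, and the source may have more. Where it says the series, first, only, none or still open, it means among the compounds named here.

Compounds measured in an assay for inhibition of serine/threonine-protein kinase PAK 4 (Homo sapiens), read by FRET and Z'-LYTE, with a stated time of 60 min, tested at 0.5 uM, in the presence of a further agent that is not named here; on this read-out higher numbers stand for a stronger effect at the one concentration tested and lower numbers for a weaker effect: compound 1 `CC(C)COC(=O)N1CCN(C(=O)c2nc(Nc3cc(C4CC4)[nH]n3)c3cc(Cl)ccc3n2)C[C@H]1C` gives 0.8%; compound 2 `CCCCCOC(=O)N1CCN(C(=O)c2nc(Nc3cc(C4CC4)[nH]n3)c3cc(Cl)ccc3n2)C[C@H]1C` gives -3.8%.

Compound 2 and compound 1 cannot be told apart on these numbers, since the step of a number 4.6 percentage points lower from compound 1 to compound 2 (within the scatter) does not exceed the scatter of repeated measurements. Compound 3 `C[C@@H]1CN(C(=O)c2nc(Nc3cc(C4CC4)[nH]n3)c3cc(Cl)ccc3n2)CCN1C(=O)OCC(Cl)(Cl)Cl` is yet to be measured; it differs from compound 2 by trichloromethyl in place of butyl on a saturated chain carbon bound to an oxygen next to a carbonyl group. For the measured compounds named here, the one measured step, a number 4.6 percentage points lower from compound 1 to compound 2 (within the scatter), changed the same place and moved nothing beyond the scatter, so for compound 3 no step beyond the scatter is expected in this assay, with a number 2.8 percentage points higher from compound 2 to compound 3 (within the scatter). Compound 3 is thus estimated at -1%, within -12% to 11%.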

Compound 3, a percentage reported as inhibition, at one concentration (the size of the read-out at that concentration, not a potency): -1.5%
Beside the measured number, compound 3's estimate is 0.5 percentage points above it, within the range that was stated.
By their numbers in this assay, from the lowest: compounds 2, 3 and 1 (each within the scatter of the next).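

Trichloromethyl in place of butyl gives a number 2.3 percentage points higher from compound 2 to compound 3 (within the scatter), and trichloromethyl in place of isopropyl gives a number 2.3 percentage points lower from compound 1 to compound 3 (within the scatter). The earlier pair compared only carbon chains, whereas these steps show that in this assay a group carrying chlorine at this place also cannot be told apart from them. Nothing available here explains this result. From the compounds shown here alone, it remains open whether an amine, a carboxylic acid or a phenyl ring at this place would give a step beyond the scatter, and whether any group here would raise the read-out clearly above that of compound 1.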